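A few compounds are considered here, and "the series" means these few. Any claim that something is new, unique, unknown or untested is made for them only; others in the source may bear on it.

In a functional assay on K562 cells (Homo sapiens) for antiproliferative activity, read by MTT assay, with a stated time of 24 h (on this read-out lower numbers stand for stronger inhibition and higher numbers for weaker inhibition), compound 1 (`COc1ccc(C(=O)/C=C/c2ccc(F)cc2)c2c1C=CC(C)(C)O2`) gives only a limit, > 10000 nM, so its position on the scale has no exact number. Compound 2 (`COc1ccc(C(=O)/C=C/c2ccc(-c3ccccc3)cc2)c2c1C=CC(C)(C)O2`) also gives only a limit, > 10000 nM. Compound 3 (`COc1ccc(C(=O)/C=C/c2ccc3ccccc3n2)c2c1C=CC(C)(C)O2`) gives a measured number, 3020 nM. The series therefore has (the limit of > 10000 nM in this assay, at which 2 of the 3 values shown sit).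

Compound 4 (`COc1ccc(C(=O)/C=C/c2ccc([N+](=O)[O-])cc2)c2c1C=CC(C)(C)O2`) follows from compound 1 by one change: nitro in place of fluoro on an aromatic carbon. This places nitro in place of fluoro on an aromatic carbon, para to a large group. For the measured compounds named here, the only measured step at this place is a step that the two limits leave unreadable from compound 1 to compound 2, which gives no size to carry over. Going by the values given here, no measured step tests nitro, so this assay offers no firm direction for this change. The expectation therefore stays close to the limit of compound 1, > 10000 nM. The estimated step is an at least 1.1-fold lower number from compound 1 to compound 4 (0.04 log units; that floor lies within the scatter), and it should be read as small and uncertain in direction. For compound 4 the expected value is 9000 nM. The estimated range for compound 4 runs from 3000 nM to 20000 nM.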

Compound 4, half-maximal inhibitory concentration: 7770 nM
Compound 4: the middle estimate sits 1.2-fold (0.06 log units) above what was measured; measured number inside the range.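

For the compounds shown here, at this place, on an aromatic carbon para to a large group, nitro gives the first exact reading in this assay: compound 4 gives 7770 nM. Going by these compounds, the change from fluoro gives an at least 1.2-fold lower number from compound 1 to compound 4 (0.10 log units; that floor lies within the scatter), and the change from phenyl gives an at least 1.2-fold lower number from compound 2 to compound 4 (0.10 log units; that floor lies within the scatter); both are floors only, so the true size of each step remains unknown. The other two readings at this place remain limits, not numbers: the limit of > 10000 nM in this assay, at which 2 of the 4 values shown sit.

On these data alone, whether an amine or a carboxylic acid at this place would read differently from nitro remains open. With only fluoro, phenyl and nitro shown here, and only nitro giving an exact number, no ranking of groups at this place can be drawn.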